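The compounds below may be only part of what the source reports. "The series", "measured", "known", "first", "only" and "open" are said of these compounds alone.

Compound 1 `Cc1ccc(CC2=NCCN2)cc1` is the lowest of the three measured compounds in an ADME assay on the whole organism (thoracic aorta) with Rattus norvegicus as the target (on this read-out higher numbers stand for larger maximal responses and lower numbers for smaller maximal responses), where compound 1 gives 14%. Its nearest neighbour in this assay is compound 3 `S=C=Nc1ccc(CC2=NCCN2)cc1I`, which gives 31%, a number that lies beyond the scatter above compound 1. Furthest away stands compound 2 `S=C=Nc1ccc(Cc2ncc[nH]2)cc1`, which in this assay gives 70%, again well beyond the scatter above compound 1. Among the measured compounds shown here, no two of these measured compounds differ in only one place, so no single step between them can be read off; the numbers simply show compound 1 at the bottom and compound 2 at the top.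

The unmeasured compound 4 `O=C(CCl)Nc1ccc(CC2=NCCN2)cc1` differs from compound 1 in one place: ((chloromethyl)carbonyl)amino in place of methyl on an aromatic carbon. For the measured compounds named here, since no measured pair mirrors this change, the expectation for compound 4 rests on the low starting point of compound 1 at 14% and on the fact that both other measured compounds sit higher. Compound 4 is expected to show a step of a number 16 percentage points higher from compound 1 to compound 4 (beyond the scatter) upward in this assay. The estimate for compound 4 is 30%, within a range of 12% to 55%.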

Compound 4, largest response reached (Emax), in percent of the reference or control that the assay uses: 41%
Estimate against measurement, compound 4: 11 percentage points below, within the range that was stated.
By their numbers in this assay, from the lowest: compound 1; then compounds 3 and 4 (each within the scatter of the next); then compound 2.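

In this assay, among the compounds shown here, ((chloromethyl)carbonyl)amino in place of methyl on the aromatic carbon gives a step of a number 27 percentage points higher from compound 1 to compound 4 (beyond the scatter), the first change in a single place that can be read. The position, para to a group of 6 heavy atoms, thus accepts a group of 5 heavy atoms in place of a single carbon, bringing in a hydrogen-bond donor and a hydrogen-bond acceptor, and the maximal response rises rather than falls. Nothing available explains this rise.

The compounds shown do not separate the contribution of the chlorine from that of the rest of the entering group, as a plain acetylamino group at this carbon would. They also leave open how an amine or a longer alkyl chain at the same place would compare.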